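A few compounds are considered here, and "the series" means these few. Any claim that something is new, unique, unknown or untested is made for them only; others in the source may bear on it.

Series notes, compounds 1 to 4.

Compound 3 `CC(C)=CCc1cc(C(=O)Nc2cc3ccc(OCCCNC(C)(C)C)c(C)c3oc2=O)ccc1O` gives 950 nM in a functional assay on MCF7 cells (Homo sapiens) for antiproliferative activity (on this read-out higher numbers stand for weaker inhibition and lower numbers for stronger inhibition), and stands lowest of the two numbers shown; compound 2 `CC(C)=CCc1cc(C(=O)Nc2cc3ccc(OCCCNCC(C)C)c(C)c3oc2=O)ccc1O` gives 1320 nM, and a 1.4-fold lower number from compound 2 to compound 3 (0.14 log units; within the scatter), a tert-butyl in place of isobutyl on the amine nitrogen. Compound 1 `CCCN(CCC)CCCOc1ccc2cc(NC(=O)c3ccc(O)c(CC=C(C)C)c3)c(=O)oc2c1C` reaches only a limit in this assay, > 50000 nM, so its value is not a number (the limit of > 50000 nM in this assay, at which 1 of the 3 values shown sits). The two steps from compound 1 are large: an at least 37-fold lower number from compound 1 to compound 2 (1.57 log units; beyond the scatter) and an at least 52-fold lower number from compound 1 to compound 3 (1.72 log units; beyond the scatter), both replacing dipropylamino with an amine carrying a hydrogen on nitrogen.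

Compound 4 `CC(C)=CCc1cc(C(=O)Nc2cc3ccc(OCCCN(C)c4ccccc4)c(C)c3oc2=O)ccc1O` differs from compound 3 by methyl(phenyl)amino in place of (tert-butyl)amino on a saturated chain carbon, three bonds along the chain from an oxygen on an aromatic ring. Methyl(phenyl)amino, like the dipropylamino of compound 1, is a fully substituted amine nitrogen, so the change runs opposite to the two large measured steps. A large rise in number is therefore expected, a 16-fold higher number from compound 3 to compound 4 (1.20 log units; beyond the scatter), with a real chance that compound 4 again reports only a limit. Compound 4 is estimated at 15000 nM, within a range of 3000 nM to 50000 nM.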

Compound 4, half-maximal inhibitory concentration: > 50000 nM
Compound 4 was reported as a limit (the forecaster's own chance of this, stated with the estimate: 30%); at least 3.3-fold (0.52 log units) between middle value and limit.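

In this assay, the change to methyl(phenyl)amino is large from both amines with a hydrogen on nitrogen (an at least 52-fold higher number from compound 3 to compound 4 (1.72 log units; beyond the scatter)) and (an at least 37-fold higher number from compound 2 to compound 4 (1.57 log units; beyond the scatter)). The result for compound 4 is a limit, not a number, and the step between compound 1 and compound 4 cannot be read, so these two groups cannot be ordered. The loss is therefore not peculiar to dipropylamino: among these four compounds, the two with a hydrogen on the amine nitrogen give numbers and the two fully substituted amines sit at the limit, with no compound going against this.

Still open, as far as these compounds go, is whether a smaller fully substituted amine such as dimethylamino, or a primary amino group, fits this split. Fully substituted amines cannot yet be ranked against each other: the limit of > 50000 nM in this assay, at which 2 of the 4 values shown sit.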